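Chloro pattern on the six-membered aromatic ring

This account rests on a few compounds, and the source may have more. Where it says the series, first, only, none or still open, it means among the compounds named here.

Measured so far in a functional assay on the whole organism (Pleural cavity) for inhibition, with Rattus norvegicus as the target, at a dose of 25 mg/kg; on this read-out lower numbers stand for less inhibition and higher numbers for more inhibition at the one dose given (going by the name of the read-out):
compound 1 `CC1(C)C(=O)N(c2ccc(Cl)cc2Cl)c2ncccc21`: 8%
compound 2 `CC1(C)C(=O)N(c2ccccc2Cl)c2ncccc21`: 3%
compound 3 `CC1(C)C(=O)N(c2cccc(Cl)c2)c2ncccc21`: 49%

Compound 3 stands highest of the three; its gaps to compound 1 and to compound 2 are both beyond the scatter. Compound 2 and compound 3 have the same atoms joined differently; the difference between the two cores is not broken down here. From compound 2 to compound 1 the change is chloro in place of hydrogen on an aromatic carbon and gives a number 5 percentage points higher from compound 2 to compound 1 (within the scatter).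

Compound 4 `CC1(C)C(=O)N(c2cc(Cl)cc(Cl)c2)c2ncccc21` has not yet been measured in this assay. It is made from compound 3 by chloro in place of hydrogen on an aromatic carbon. This is the same kind of change as from compound 2 to compound 1, but not the same: in compound 1 the new chloro is para to a large group, in compound 4 it is meta to a large group.

Because the earlier step of a number 5 percentage points higher from compound 2 to compound 1 (within the scatter) stayed within the scatter, a small step is expected here as well. The expected step is a number 4 percentage points lower from compound 3 to compound 4 (within the scatter). Compound 4 is therefore estimated at 45%, between 25% and 65%.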

Compound 4, a percentage reported as inhibition, in the whole organism at one dose (the size of the read-out at that dose, not a potency): 33%
Beside the measured number, compound 4's estimate is 12 percentage points above it; the range from low to high includes it.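

In this assay, chloro in place of hydrogen on an aromatic carbon gives a number 16 percentage points lower from compound 3 to compound 4 (beyond the scatter), so the extra chloro lowers the read-out on this core. The change does not carry over with the same size from one core to the other: the same change on two cores in this assay, a number 5 percentage points higher (within the scatter) from compound 2 to compound 1 and a number 16 percentage points lower (beyond the scatter) from compound 3 to compound 4, 21 percentage points apart, beyond the scatter of two such steps This shows that, in these two pairs, the step seen on one core does not predict the step on the other, but it does not show why they differ: the new chloro also sits in a different place in each pair (in compound 4 it is meta to a chloro group and meta to a large group), and two steps at one dose establish no rule for further cores.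

Every substituent shown on this ring is chloro, so it remains open how a fluoro, methoxy, trifluoromethyl or amine group would behave in the place of chloro on the core of compound 3. Also open, going by these compounds, is whether the gem-dimethyl carbon of the shared core could carry a longer chain, such as ethyl, with the read-out held.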